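A few compounds are considered here, and "the series" means these few. Any claim that something is new, unique, unknown or untested is made for them only; others in the source may bear on it.

Measured so far:
compound 1, `COc1ccc2c(=O)c(/C=C/C(=O)NCc3ccccc3F)coc2c1` — 34000 nM
compound 2, `COc1ccc2c(=O)c(/C=C/C(=O)NCc3ccc(F)cc3F)coc2c1` — > 100000 nM

In a functional assay (QGY7701 cells, Homo sapiens) for inhibition, read by MTT assay, with a stated time of 48 h (on this read-out lower numbers stand for stronger inhibition and higher numbers for weaker inhibition), compound 1 gives 34000 nM. For compound 2 only a limit of this assay is recorded, > 100000 nM. The step of an at least 2.9-fold higher number from compound 1 to compound 2 (0.46 log units; beyond the scatter) is therefore bounded by the limit of > 100000 nM in this assay, at which 1 of the 2 values shown sits. Compound 3, `CCOc1ccc(NC(=O)/C=C/c2coc3cc(OC)ccc3c2=O)cc1`, differs from compound 2 by 4-ethoxyphenyl in place of 2,4-difluorobenzyl on an amide-type nitrogen. Among the measured compounds shown here, no measured step covers such an exchange; the one step known, an at least 2.9-fold higher number from compound 1 to compound 2 (0.46 log units; beyond the scatter), concerns a fluoro only. Compound 2 stands at the limit, so compound 3 is expected near it, estimated at 60000 nM within 15000 nM to 200000 nM, meaning an at least 1.6-fold lower number from compound 2 to compound 3 (0.22 log units; that floor lies within the scatter), with a fair chance of another limit.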

Compound 3, half-maximal inhibitory concentration: > 100000 nM
Compound 3 gave a limit, no number (the forecaster's own chance of this, stated with the estimate: 40%); middle value at least 1.6-fold (0.22 log units) away from the limit.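

In this assay, 4-ethoxyphenyl in place of 2-fluorobenzyl on an amide-type nitrogen gives an at least 2.9-fold higher number from compound 1 to compound 3 (0.46 log units; beyond the scatter), so a change beyond a single fluoro also leaves the read-out short of a number. The step from compound 2 to compound 3 joins two limits and cannot be read. Of the compounds shown, only compound 1 gives a number rather than a limit: the limit of > 100000 nM in this assay, at which 2 of the 3 values shown sit.

As far as these compounds go, how far compound 2 and compound 3 lie past the limit stays open. Also open, from the compounds shown here alone, is how an unsubstituted benzyl or a 2-phenylethyl chain would read on this nitrogen.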